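The source may report more compounds than this note shows. Statements on the series, on what has been measured and on what is new or still open speak of the compounds shown alone.

Measured so far:
compound 1 `CC(C)c1cccc(OC(=O)c2cn(-c3ccccc3)nc2-c2cccnc2)c1` — in a functional assay on MDA-MB-231 cells (Homo sapiens) for cytotoxicity, read by MTT assay, with a stated time of 48 h (a higher number here means a weaker inhibitor, a lower number a stronger inhibitor), compound 1 gives > 100000 nM
compound 2 `CC(C)c1cccc(OC(=O)c2cn(-c3ccccc3)nc2-c2ccncc2)c1` — in this assay compound 2 gives > 100000 nM

Both of these values are limits of the assay, not numbers. For compound 1 the value in this assay is a limit. For compound 2 the value in this assay is likewise a limit. The step that the two limits leave unreadable from compound 1 to compound 2 therefore cannot be read; the limit of > 100000 nM in this assay, at which 2 of the 2 values shown sit, summarises where the shown values sit.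

Compound 2 stands at the limit of this assay and nowhere else in the shown numbers, so its position cannot be placed more finely.

Compound 3 `O=C(O)c1cn(-c2ccccc2)nc1-c1ccncc1` differs from compound 2 by hydrogen in place of 3-isopropylphenyl on an oxygen next to a carbonyl group. Going by the values given here, no measured step concerns this change; the only step, a step that the two limits leave unreadable from compound 1 to compound 2, is at a different position and has no readable size. With every shown value at the limit, the series gives no sign of a change in potency to carry over.

Compound 3 is expected to stay at the limit, and the step that the limit leaves unreadable from compound 2 to compound 3 is estimated as no movement beyond the scatter. The estimate for compound 3 in this assay is 150000 nM, with a range from 50000 nM to 500000 nM.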

Compound 3, half-maximal inhibitory concentration: > 100000 nM
Compound 3 was reported as a limit; the forecaster's own chance of this, stated with the estimate: 85%; the middle value lies beyond the limit too.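

In this assay compound 3 gives > 100000 nM, which is a limit. Going by these compounds alone, the step between compound 2 and compound 3 therefore cannot be read, and no new step follows from this result. The compounds shown leave open which change, if any, would bring a value inside the measurable range of this assay, because all of them share one position: the limit of > 100000 nM in this assay, at which 3 of the 3 values shown sit.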